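The source may hold more compounds than are shown below. What is called first, only, known or untested is meant among the compounds shown, and "the series" means these compounds.

In a functional assay on the whole organism for antagonist activity, with Mus musculus as the target, in the maximal electroshock model (on this read-out higher numbers stand for an effect only at larger amounts of compound and lower numbers for an effect already at smaller amounts), compound 1 (`COC(=O)NC1=NC(c2ccccc2)CN1C`) gives 107 mg/kg and compound 2 (`COC(=O)NC1=NC(c2ccccc2F)CN1C`) gives 74 mg/kg. Compound 2 therefore stands level with compound 1 within the scatter (a 1.4-fold lower number from compound 1 to compound 2 (0.16 log units; within the scatter)). Compound 3 (`CC(C)OC(=O)NC1=NC(c2ccccc2F)CN1C`) differs from compound 2 by isopropyl in place of methyl on an oxygen next to a carbonyl group. Among the compounds with values here, the one measured step is fluoro in place of hydrogen on an aromatic carbon, so no measured step covers this change. No shift beyond the scatter is expected in this assay, and the expected step is small (a 1.1-fold lower number from compound 2 to compound 3 (0.02 log units; within the scatter)). Compound 3 is estimated at 70 mg/kg (expected range 35 mg/kg to 140 mg/kg).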

Compound 3, dose for half-maximal effect: 23 mg/kg
Beside the measured number, compound 3's estimate is 3.0-fold (0.48 log units) above it; the measured number lies below the stated range.
By their numbers in this assay, from the lowest: compound 3; then compounds 2 and 1 (each within the scatter of the next).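

Isopropyl in place of methyl on an oxygen next to a carbonyl group gives a 3.2-fold lower number from compound 2 to compound 3 (0.51 log units; beyond the scatter) in this assay, the only step shown that lies beyond the scatter. This place in the molecule therefore responds to a change of alkyl group, at least with the fluoro substituent present. Nothing measured bears on the reason for this step.

As far as these compounds go, whether a longer chain such as butyl, or a cyclopropyl ring, would move the number further remains open. So does whether an amine in place of isopropoxy would keep the effect, or whether the same step holds in the core of compound 1, without the fluoro.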